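Series notes: replacing the aminomethyl arm with a carboxy group

A few compounds are considered here, and "the series" means these few. Any claim that something is new, unique, unknown or untested is made for them only; others in the source may bear on it.

Compound 1 `CCNC(=O)c1noc(-c2cc(C(C)C)c(O)cc2O)c1-c1cc(CNC(C)C)no1` is the reference point here. Among the measured compounds shown here, in a functional assay on A2780 cells (Homo sapiens) for inhibition (a higher number here means a weaker inhibitor, a lower number a stronger inhibitor), compound 1 gives 38 nM, the lowest of the two numbers measured so far. Its nearest neighbour is compound 2 `CCNC(=O)c1noc(-c2cc(C(C)C)c(O)cc2O)c1-c1cc(CN2CCCC2)no1`, which in this assay gives 55 nM; the step of a 1.4-fold higher number from compound 1 to compound 2 (0.16 log units; within the scatter) is within the scatter, so the two compounds are read as equivalent.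

Compound 3 `CCNC(=O)c1noc(-c2cc(C(C)C)c(O)cc2O)c1-c1cc(C(=O)O)no1` has not yet been measured. It differs from compound 1 by carboxy in place of (isopropylamino)methyl on an aromatic carbon; cut one bond further out, the change reads 3-((isopropylamino)methyl)-1,2-oxazol-5-yl to 3-carboxy-1,2-oxazol-5-yl. For the measured compounds named here, the only measured step, from compound 1 to compound 2, exchanges one amine for another at this same position and leaves the number unchanged within scatter; it does not cover removal of the whole (isopropylamino)methyl arm in favour of a carboxy group. Going by the values given here, the expectation for compound 3 therefore rests on no direct precedent and is held loosely: a weaker number is expected, a 3.9-fold higher number from compound 1 to compound 3 (0.60 log units; beyond the scatter), with a wide range. Compound 3 is estimated at 150 nM in this assay, between 30 nM and 800 nM.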

Compound 3, half-maximal inhibitory concentration: 20000 nM
Compound 3: the middle estimate sits 130-fold (2.12 log units) below what was measured; the whole stated range lies below it.
By their numbers in this assay, from the lowest: compounds 1 and 2 (each within the scatter of the next); then compound 3.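

In this assay, the aromatic carbon next to the ring nitrogen proves far less tolerant of change than the amine exchange alone suggested: replacing either arm with carboxy gives a large step (a 530-fold higher number from compound 1 to compound 3 (2.72 log units; beyond the scatter)) and (a 360-fold higher number from compound 2 to compound 3 (2.56 log units; beyond the scatter)), whereas exchanging one amine for the other stays within the scatter (a 1.4-fold higher number from compound 1 to compound 2 (0.16 log units; within the scatter)). The (isopropylamino)methyl and (pyrrolidin-1-yl)methyl arms are therefore equivalent here, but this equivalence extends only to these two amines and does not reach the carboxy group. No measurement on these compounds accounts for the size of the step.

The three compounds do not separate the loss of the amine nitrogen from the shortening of the arm or the entry of the carboxylic acid, a question that a hydroxymethyl group, a primary amide or a methyl ester on the same carbon would help to resolve. They also leave open whether an unsubstituted aminomethyl group or an amine on a longer chain would keep the number of compound 1 (38 nM).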